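The source may hold more compounds than are shown below. What is called first, only, known or untested is meant among the compounds shown, and "the series" means these compounds.

Measured compounds in an assay on membranes from liver for displacement of a labelled ligand from Glucagon receptor (Mus musculus), read by scintillation counting, with a stated time of 60 min; on this read-out higher numbers stand for weaker inhibition and lower numbers for stronger inhibition:
Compound 3 `CC(C)(C)CC[C@H](c1ccc(C(=O)NCc2nn[nH]n2)cc1)N1C(=O)C(c2ccc(F)cc2)=N[C@]12CC[C@@H](C(C)(C)C)CC2` — compound 3 gives 90 nM.
Compound 1 `C[C@H](c1ccc(C(=O)NCCC(=O)O)cc1)N1C(=O)C(c2cccc(C3CC3)c2)=N[C@]12CC[C@@H](C(C)(C)C)CC2` — compound 1 gives 1700 nM.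
Compound 2 `CC(C)(C)[C@H]1CC[C@]2(CC1)N=C(c1cccc(Cl)c1)C(=O)N2Cc1ccc(C(=O)NCCC(=O)O)cc1` — compound 2 gives > 10000 nM, which is a limit of this assay and not a number.

Compound 3 holds the lowest of the two numbers shown in this assay; compound 1, the nearest, sits at a higher number, beyond the scatter. Compound 4 `CC(C)(C)CC[C@H](c1ccc(C(=O)NCc2nn[nH]n2)cc1)N1C(=O)C(c2cnccc2C(F)(F)F)=N[C@]12CC[C@@H](C(C)(C)C)CC2` differs from compound 3 by 4-(trifluoromethyl)pyridin-3-yl in place of 4-fluorophenyl on a carbon with a double bond to nitrogen. For the measured compounds named here, no measured pair isolates this change, so the expectation rests on compound 3 alone. The step is expected to be small, a 1.7-fold higher number from compound 3 to compound 4 (0.22 log units; within the scatter), not clearly beyond the scatter. Compound 4 is expected to give 150 nM, within 40 nM to 600 nM.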

Compound 4, half-maximal inhibitory concentration: 96 nM
Compound 4: middle estimate off by 1.6-fold (0.19 log units), on the high side; low and high end bracket the measured number.
By their numbers in this assay, from the lowest: compounds 3 and 4 (each within the scatter of the next); then compound 1. At a limit, above all of these: compound 2.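

In this assay, the carbon with a double bond to nitrogen takes 4-(trifluoromethyl)pyridin-3-yl in place of 4-fluorophenyl with a 1.1-fold higher number from compound 3 to compound 4 (0.03 log units; within the scatter), the first step read at this position. Compounds 3 and 4 cannot be told apart here, so this place accommodates a ring with a hetero atom and more heavy atoms without a step beyond the scatter. No measurement shown gives a cause for this step.

On these data alone, whether this tolerance extends to an amine, a carboxylic acid or a nitrile on this ring stays open. A saturated ring or an open alkyl chain at this place also remains untested among the compounds shown.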